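Two methyls on the amide ring of compound 1

A few compounds are considered here, and "the series" means these few. Any claim that something is new, unique, unknown or untested is made for them only; others in the source may bear on it.

Among the compounds with values here, compound 1 `Cc1ccc(C(=O)Nc2cccc(-c3oc4cc(-c5ccc(F)cc5)ccc4c(=O)c3O)c2)cc1` gives 2400 nM in a functional assay on MCF7 cells (Homo sapiens) for antiproliferative activity, read by CCK-8 assay, with a stated time of 72 h (on this read-out higher numbers stand for weaker inhibition and lower numbers for stronger inhibition), the second-highest of the three numbers so far. Compound 2 `Cc1ccccc1C(=O)Nc1cccc(-c2oc3cc(-c4ccc(F)cc4)ccc3c(=O)c2O)c1` gives 2280 nM, and compound 3 `CCc1ccc(C(=O)Nc2cccc(-c3oc4cc(-c5ccc(F)cc5)ccc4c(=O)c3O)c2)cc1` gives 22800 nM. The change to compound 4 `Cc1cc(C)cc(C(=O)Nc2cccc(-c3oc4cc(-c5ccc(F)cc5)ccc4c(=O)c3O)c2)c1` is 3,5-dimethylphenyl in place of 4-methylphenyl on a carbonyl carbon. Within the data shown here, two measured steps bear on it: relocating the methyl, a 1.1-fold lower number from compound 1 to compound 2 (0.02 log units; within the scatter), and growing the methyl into an ethyl, a 9.5-fold higher number from compound 1 to compound 3 (0.98 log units; beyond the scatter). Relocating a methyl changed nothing, whereas adding a further methyl to the same ring clearly weakened inhibition, and compound 4 also carries an extra methyl. A modest rise in the number is therefore expected, a 2.1-fold higher number from compound 1 to compound 4 (0.32 log units; beyond the scatter). Compound 4 is estimated at 5000 nM, within the range 1500 nM to 20000 nM.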

Compound 4, half-maximal inhibitory concentration: 20400 nM
The estimate for compound 4 lay 4.1-fold (0.61 log units) below the measured number, and the stated range ends below it.
By their numbers in this assay, from the lowest: compounds 2 and 1 (each within the scatter of the next); then compounds 4 and 3 (each within the scatter of the next).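

Replacing 4-methylphenyl with 3,5-dimethylphenyl on the carbonyl carbon gives an 8.5-fold higher number from compound 1 to compound 4 (0.93 log units; beyond the scatter). The second methyl therefore matters as much as the extra carbon of 4-ethylphenyl, and those two groups cannot be told apart: a 1.1-fold lower number from compound 3 to compound 4 (0.05 log units; within the scatter). The 2-methylphenyl compound shows a similar gap, an 8.9-fold higher number from compound 2 to compound 4 (0.95 log units; beyond the scatter), so both single-methyl groups stay together, apart from the two with more carbon. No measurement shown gives a reason for this gap. Going by these compounds, whether an amine or a carboxylic acid on this ring would also raise the number remains open.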